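From phenoxy to chloro on compound 3

This account rests on a few compounds, and the source may have more. Where it says the series, first, only, none or still open, it means among the compounds named here.

In an ADME assay on BJ cells (Homo sapiens) for cytotoxicity, read by luminescence, with a stated time of 72 h (on this read-out higher numbers stand for an effect only at larger amounts of compound and lower numbers for an effect already at smaller amounts), compound 3 `CCOC(=O)c1c(-c2cccc(Oc3ccccc3)c2)[nH]c2cc(OC)c(Cl)cc2c1=O` gives > 21500 nM, which is a limit and not a number. Compound 2 `CCOC(=O)c1c(-c2cccc(OC)c2)[nH]c2cc(OC)c(Cl)cc2c1=O` gives > 21500 nM, also a limit. Compound 1 `CCOC(=O)c1c(-c2cccc(Cl)c2)[nH]c2cc(OC)ccc2c1=O` gives > 21500 nM, again a limit. The whole set therefore rests on (the limit of > 21500 nM in this assay, at which 3 of the 3 values shown sit). Compound 4 `CCOC(=O)c1c(-c2cccc(Cl)c2)[nH]c2cc(OC)c(Cl)cc2c1=O` differs from compound 3 by chloro in place of phenoxy on an aromatic carbon, with chloro in place of phenoxy on an aromatic carbon. Going by the values given here, the one measured step that bears on this, a step that the two limits leave unreadable from compound 2 to compound 3, has no readable size, so no step beyond the scatter is expected in this assay. The estimated change is a step that the limit leaves unreadable from compound 3 to compound 4. Compound 4 is expected at about 25000 nM, with an estimated range of 14000 nM to 45000 nM.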

Compound 4, half-maximal effective concentration: > 21500 nM
Compound 4: no number, only a limit; the forecaster's own chance of this, stated with the estimate: 90%; the middle value does not contradict the limit.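

In this assay no step can be read between compound 4 and compound 1, compound 2 or compound 3, since all four rest on a limit: the limit of > 21500 nM in this assay, at which 4 of the 4 values shown sit. The compounds shown leave open at what concentration, if any, each reaches its half-maximal effect.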